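Series note: neopentyl for 4-cyanobenzyl in compound 4

The source may hold more compounds than are shown below. What is called first, only, known or untested is meant among the compounds shown, and "the series" means these compounds.

Measured in a functional assay on CHOK cells for antagonist activity at growth hormone secretagogue receptor type 1 (Homo sapiens), read by calcium flux; a lower number here means a stronger inhibitor, a higher number a weaker inhibitor:
compound 1 `Nc1nc(N)c(-c2ccc(NCc3ccc([N+](=O)[O-])cc3)cc2)c(COCc2ccccc2)n1` gives 5.8 nM
compound 2 `Nc1nc(N)c(-c2ccc(NCc3ccnc(Cl)c3)cc2)c(COCc2ccccc2)n1` gives 3.6 nM
compound 3 `N#Cc1ccc(CNc2ccc(-c3c(N)nc(N)nc3COCc3ccccc3)cc2)cc1` gives 19 nM

Compound 3 stands highest of the three numbers in this assay, shown by a 3.3-fold higher number from compound 1 to compound 3 (0.52 log units; beyond the scatter) and a 5.3-fold higher number from compound 2 to compound 3 (0.72 log units; beyond the scatter). Compound 4 `CC(C)(C)CNc1ccc(-c2c(N)nc(N)nc2COCc2ccccc2)cc1` differs from compound 3 by tert-butyl in place of 4-cyanophenyl on a saturated chain carbon bound to a nitrogen on an aromatic ring. Among the measured compounds shown here, no measured step removes the aromatic ring at this position; the nearest precedents only exchange one aromatic group for another, a 1.6-fold lower number from compound 1 to compound 2 (0.21 log units; within the scatter) and a 5.3-fold higher number from compound 2 to compound 3 (0.72 log units; beyond the scatter), so changes at this carbon have moved the number by at most modest amounts. With the ring lost entirely, a weaker inhibitor than compound 3 is expected, estimated as a 3.2-fold higher number from compound 3 to compound 4 (0.50 log units; beyond the scatter), with wide uncertainty. Compound 4 is therefore expected to give about 60 nM in this assay, within a range of 15 nM to 300 nM.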

Compound 4, half-maximal inhibitory concentration: 700 nM
Compound 4: middle estimate off by 12-fold (1.07 log units), on the low side; the measured number lies above the stated range.
By their numbers in this assay, from the lowest: compounds 2 and 1 (each within the scatter of the next); then compound 3; then compound 4.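

In this assay, the step of a 37-fold higher number from compound 3 to compound 4 (1.57 log units; beyond the scatter) and the steps of a 190-fold higher number from compound 2 to compound 4 (2.29 log units; beyond the scatter) and a 120-fold higher number from compound 1 to compound 4 (2.08 log units; beyond the scatter) are all large, and each exceeds any step among compound 1, compound 2 and compound 3. This position therefore tolerates exchange of one aromatic group for another far better than loss of the aromatic ring in favour of tert-butyl.

As far as these compounds go, whether the ring as such or its aromatic character matters stays open, and cyclohexyl on the same carbon would separate the two. No measurement shown here explains the loss.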